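A few compounds are considered here, and "the series" means these few. Any claim that something is new, unique, unknown or untested is made for them only; others in the source may bear on it.

Compound 1 `COC(=O)N[C@H](C(=O)N1CCC[C@H]1C(=O)Nc1ccc([C@H]2CC[C@H](c3ccc(NC(=O)[C@@H]4CCCN4C(=O)[C@@H](NC(=O)OC)C(C)C)cc3)N2c2ccc(C(F)(F)F)cc2)cc1)C(C)C`: 4.83 mL/min/kg
Compound 2 `COC(=O)N[C@H](C(=O)N1CCC[C@H]1C(=O)Nc1ccc([C@@H]2CC[C@@H](c3ccc(NC(=O)[C@@H]4CCCN4C(=O)[C@@H](NC(=O)OC)[C@H]4CCOC4)cc3)N2c2ccc(F)cc2)cc1)[C@H]1CCOC1`: 31.7 mL/min/kg
Compound 3 `COC(=O)N[C@H](C(=O)N1CCC[C@H]1C(=O)Nc1ccc([C@H]2CC[C@H](c3ccc(NC(=O)[C@@H]4CCCN4C(=O)[C@@H](NC(=O)OC)[C@H]4CCOC4)cc3)N2c2ccc(F)cc2)cc1)[C@H]1CCOC1`: 66.7 mL/min/kg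

In an ADME assay on the whole organism for pharmacokinetics, with Rattus norvegicus as the target, at a dose of 3 mg/kg by the intravenous route (a lower number here means slower removal, a higher number faster removal of the compound), compound 1 gives the lowest of the three numbers, with compound 2 well above it and compound 3 higher still. Within the data shown here, the only measured step, a 2.1-fold higher number from compound 2 to compound 3 (0.32 log units; beyond the scatter), concerns a change in configuration alone, as the fact that compounds 2 and 3 differ only in the configuration as drawn shows, and does not touch the change followed here. Compound 4 `COC(=O)N[C@H](C(=O)N1CCC[C@H]1C(=O)Nc1ccc([C@H]2CC[C@H](c3ccc(NC(=O)[C@@H]4CCCN4C(=O)[C@@H](NC(=O)OC)C(C)C)cc3)N2c2ccc(F)cc2)cc1)C(C)C` differs from compound 1 by fluoro in place of trifluoromethyl on an aromatic carbon. Among the measured compounds shown here, compounds 2 and 3 also carry fluoro, but they differ from compound 1 in other places as well, so no measured step speaks directly to this change. A modest rise in clearance is expected, small enough that it may stay within the usual scatter. The estimate for compound 4 is 9 mL/min/kg, with a range from 4 mL/min/kg to 25 mL/min/kg, which means an expected step of a 1.9-fold higher number from compound 1 to compound 4 (0.27 log units; within the scatter).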

Compound 4, clearance in the Rattus norvegicus assay: 2.17 mL/min/kg
Estimate against measurement, compound 4: 4.1-fold (0.62 log units) above, outside the stated range (below it).
By their numbers in the Rattus norvegicus assay, from the lowest: compound 4; then compound 1; then compound 2; then compound 3.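

Among these compounds, in the Rattus norvegicus assay, fluoro in place of trifluoromethyl on this aromatic carbon gives a 2.2-fold lower number from compound 1 to compound 4 (0.35 log units; beyond the scatter), the first direct reading of this change, and it shows that clearance need not rise with this swap on this core. In a physicochemical assay for solubility, in phosphate buffer, measured as kinetic solubility, at pH 7.2 (a higher number here means a more soluble compound, a lower number a less soluble compound), compound 1 gives 3200 nM and compound 4 gives 6000 nM, two values within the usual scatter of each other. Nothing measured here explains the clearance step.

Open, as far as these compounds go, is how a chlorine atom or a nitrile at this place would compare. Also open, from the compounds shown here alone, is whether trifluoromethyl in place of fluoro on compound 2 or compound 3 would shift clearance in the same way.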